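This account rests on a few compounds, and the source may have more. Where it says the series, first, only, none or still open, it means among the compounds named here.

Among the measured compounds shown here, in a functional assay on HL-60 cells (Homo sapiens) for inhibition, read by MTT assay, with a stated time of 48 h, tested at 10 uM (a lower number here means less inhibition of growth, a higher number more inhibition of growth at the concentration tested), compound 1 `Cc1cc(=O)c2c(O)c(CN3CCC(N4CCCCC4)CC3)c(O)c([C@H]3CCN(C)C[C@H]3O)c2o1` gives 34% and compound 2 `Cc1cc(=O)c2c(O)c(CN3CCC(Cc4ccccc4)CC3)c(O)c([C@H]3CCN(C)C[C@H]3O)c2o1` gives 28%, so compound 2 stands within the usual scatter of the only other measured compound. Compound 3 `Cc1cc(=O)c2c(O)c(CN3CCC(c4ccccc4)CC3)c(O)c([C@H]3CCN(C)C[C@H]3O)c2o1` differs from compound 2 by one change, phenyl in place of benzyl on a saturated ring carbon. For the measured compounds named here, the one measured step at that same ring carbon (a number 6 percentage points lower from compound 1 to compound 2 (within the scatter)) stays within the scatter, so no step beyond the scatter is expected in this assay here. The estimated change (a number 2 percentage points higher from compound 2 to compound 3 (within the scatter)) is expected to be small. The estimate for compound 3 is 30% (expected range 18% to 43%).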

Compound 3, percent growth inhibition at one concentration: 26%
Beside the measured number, compound 3's estimate is 4 percentage points above it, within the range that was stated.
By their numbers in this assay, from the lowest: compounds 3, 2 and 1 (each within the scatter of the next).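

In this assay phenyl in place of benzyl gives a number 2 percentage points lower from compound 2 to compound 3 (within the scatter) and phenyl in place of piperidin-1-yl gives a number 8 percentage points lower from compound 1 to compound 3 (within the scatter) on this saturated ring carbon. All three groups at this position, the two aromatic ones and the saturated nitrogen ring, therefore read alike within the scatter, so neither the carbon link of benzyl nor the ring nitrogen of piperidin-1-yl shows an effect here. Nothing available explains this result. On these data alone, whether a carboxylic acid, a primary amine or a longer chain such as 2-phenylethyl on this carbon would move the number beyond the scatter stays open.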